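Cyano to ethynyl exchange, cytotoxicity notes

A few compounds are considered here, and "the series" means these few. Any claim that something is new, unique, unknown or untested is made for them only; others in the source may bear on it.

Measured so far in a functional assay on NCI-H522 cells (Homo sapiens) for cytotoxicity, with a stated time of 3 days; on this read-out lower numbers stand for stronger inhibition and higher numbers for weaker inhibition:
compound 1, `C=Cc1nc2ccccc2o1`: > 40000 nM, a limit of the assay rather than a number
compound 2, `N#Cc1nccs1`: > 40000 nM, likewise a limit of the assay

Among the measured compounds shown here, both entries sit at the limit of > 40000 nM in this assay, at which 2 of the 2 values shown sit, so no step between measured compounds can be drawn from them. For the measured compounds named here, compound 2 stands only as a limit in this assay, and the one further value shown is a limit as well. Compound 3, `C#Cc1nccs1`, has not been measured. It differs from compound 2 by ethynyl in place of cyano on an aromatic carbon. Going by the values given here, with two limits and no measured step to go on, the expected step in this assay is a step that the limit leaves unreadable from compound 2 to compound 3, none beyond the scatter. Compound 3 is therefore estimated at 60000 nM in this assay, within 25000 nM to 150000 nM, and the result is expected most likely to be reported again only as a limit.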

Compound 3, half-maximal inhibitory concentration: > 40000 nM
Compound 3 was reported as a limit; the forecaster's own chance of this, stated with the estimate: 85%; the middle value is on the limit's open side.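

Compound 2 and compound 3 both stand only as limits of the assay, and no step between them can be read: the limit of > 40000 nM in this assay, at which 3 of the 3 values shown sit.

The compounds shown leave open whether ethynyl in place of cyano on an aromatic carbon changes the result in this assay at all.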